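Stereocentre inversion between compound 3 and compound 4

A few compounds are considered here, and "the series" means these few. Any claim that something is new, unique, unknown or untested is made for them only; others in the source may bear on it.

Compound 3 `COC(=O)[C@H](NC(=O)c1[nH]cnc1C(=O)Nc1ccc(Cl)c(Cl)c1)c1ccccc1` is measured in a functional assay on HL-60 cells (Homo sapiens), with a stated time of 4 days (a lower number here means a stronger inhibitor, a higher number a weaker inhibitor), at 10800 nM. Compound 1 `C[C@@H](NC(=O)c1[nH]cnc1C(=O)Nc1ccc(Cl)c(Cl)c1)c1ccccc1` gives 5900 nM in this assay, and the gap to compound 3 lies within the usual scatter, so the two stand together. Compound 2 `COC(=O)[C@@H](C)NC(=O)c1[nH]cnc1C(=O)Nc1ccc(Cl)c(Cl)c1` reaches only a limit of this assay, > 62500 nM, and no number is known for it (the limit of > 62500 nM in this assay, at which 1 of the 3 values shown sits).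

The measured steps are both exchanges of groups: an at least 10-fold higher number from compound 1 to compound 2 (1.02 log units; beyond the scatter), and an at least 5.7-fold lower number from compound 2 to compound 3 (0.76 log units; beyond the scatter). Neither of them concerns the configuration of the stereocentre.

Compound 4 `COC(=O)[C@@H](NC(=O)c1[nH]cnc1C(=O)Nc1ccc(Cl)c(Cl)c1)c1ccccc1` differs from compound 3 as follows: the two compounds have the same atoms and bonds and differ only in configuration as drawn: 1 of 1 stereo elements differ; a stereocentre at a saturated chain carbon is drawn R in compound 3 and S in compound 4. For the measured compounds named here, no measured step bears on such an inversion, so the size and direction of its effect in this assay cannot be read from the numbers at hand; enantiomer pairs can sit close together or far apart. The working expectation is therefore a number near that of compound 3, with a wide margin: the step of a 1.4-fold higher number from compound 3 to compound 4 (0.14 log units; within the scatter) is expected to be small. The estimate for compound 4 in this assay is 15000 nM, expected to fall between 3000 nM and 62500 nM.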

Compound 4, half-maximal inhibitory concentration: 6800 nM
Compound 4: the middle estimate sits 2.2-fold (0.34 log units) above what was measured, within the range that was stated.
By their numbers in this assay, from the lowest: compounds 1, 4 and 3 (each within the scatter of the next). At a limit, above all of these: compound 2.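

In this assay, inversion of the stereocentre at a saturated chain carbon gives a 1.6-fold lower number from compound 3 to compound 4 (0.20 log units; within the scatter), so this pair shows no difference beyond the scatter between the two drawn configurations, and it is the first reading of configuration in the series: the fact that compounds 3 and 4 differ only in the configuration as drawn

With phenyl kept on this carbon, methoxycarbonyl in place of methyl gives a 1.2-fold higher number from compound 1 to compound 4 (0.06 log units; within the scatter), so that exchange also stays within the scatter. Of the compounds shown, only compound 2 has no phenyl on this carbon, and it alone stands at a limit of this assay, not at a number: the limit of > 62500 nM in this assay, at which 1 of the 4 values shown sits.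

The only pair of mirror-image configurations shown is compound 3 and compound 4, so it remains open whether configuration at this carbon also makes no difference beyond the scatter when a group other than phenyl sits there. Also open, going by these compounds, is what a carboxylic acid in place of the methoxycarbonyl, or a benzyl group in place of the phenyl, would do to the number at this position.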